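Compound 1 to compound 4: a dimethoxyphenyl swap

This account rests on a few compounds, and the source may have more. Where it says the series, first, only, none or still open, it means among the compounds named here.

In an ADME assay on L6 cells (Rattus norvegicus) for cytotoxicity, read by resazurin assay (a higher number here means a weaker inhibitor, a lower number a stronger inhibitor), compound 1 `N=C(N)c1ccc2[nH]c(-c3ccc4nc(-c5ccccc5F)[nH]c4c3)nc2c1` gives 26.8 ug/mL and compound 3 `COc1cc(OC)cc(-c2nc3ccc(-c4nc5cc(C(=N)N)ccc5[nH]4)cc3[nH]2)c1` gives 25.5 ug/mL, so these two share the upper end of the three numbers. Going by the values given here, compound 2 `CC(C)(C)c1ccc(-c2nc3ccc(-c4nc5cc(C(=N)N)ccc5[nH]4)cc3[nH]2)cc1` gives 13 ug/mL and is the only compound clearly apart from compound 1. The move to compound 4 `COc1ccc(-c2nc3ccc(-c4nc5cc(C(=N)N)ccc5[nH]4)cc3[nH]2)cc1OC` is 3,4-dimethoxyphenyl in place of 2-fluorophenyl on an aromatic carbon at the same place on the core. Among the compounds with values here, two measured steps bear on it. The swap to 3,5-dimethoxyphenyl gave a 1.1-fold lower number from compound 1 to compound 3 (0.02 log units; within the scatter) and is the closest case: compound 3 also carries a dimethoxyphenyl group. The swap to 4-(tert-butyl)phenyl gave a 2.1-fold lower number from compound 1 to compound 2 (0.31 log units; beyond the scatter) and stays modest. No step beyond the scatter is therefore expected in this assay, at most a slight drift toward a lower number. The expected step is a 1.2-fold lower number from compound 1 to compound 4 (0.07 log units; within the scatter) on this reasoning. Compound 4 is expected at 23 ug/mL as an estimate, with an estimated range from 11 ug/mL to 45 ug/mL for the measurement.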

Compound 4, half-maximal inhibitory concentration: > 90 ug/mL
Compound 4: only a limit was reported (the forecaster's own chance of this, stated with the estimate: 3%); middle value at least 3.9-fold (0.59 log units) away from the limit.
By their numbers in this assay, from the lowest: compounds 2, 3 and 1 (each within the scatter of the next, the first and the last beyond it). At a limit, above all of these: compound 4.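

In this assay, compound 4 carries a limit and not a number: the limit of > 90 ug/mL in this assay, at which 1 of the 4 values shown sits.

Going by these compounds alone, at this aromatic carbon between two ring nitrogen atoms, 3,4-dimethoxyphenyl gives an at least 3.3-fold higher number from compound 1 to compound 4 (0.52 log units; beyond the scatter) and an at least 6.9-fold higher number from compound 2 to compound 4 (0.84 log units; beyond the scatter), so the spread at this place in this assay is wider than the earlier steps showed. The arrangement of the two methoxy groups matters here, and not only their presence: 3,4-dimethoxyphenyl in place of 3,5-dimethoxyphenyl gives an at least 3.5-fold higher number from compound 3 to compound 4 (0.54 log units; beyond the scatter), although both groups are dimethoxyphenyl.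

The compounds shown leave open whether this shift belongs to the 3,4-dimethoxyphenyl group as a whole or to one of its two methoxy groups, and the limit gives the step no upper end. As far as these compounds go, how an amine or a carboxylic acid on this phenyl ring would read in this assay also stays open.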